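This account rests on a few compounds, and the source may have more. Where it says the series, first, only, none or still open, it means among the compounds named here.

Working notes on the series in a functional assay on HL-60 cells (Homo sapiens) for cytotoxicity, read by WST assay, with a stated time of 48 h; on this read-out lower numbers stand for stronger inhibition and higher numbers for weaker inhibition.

Compound 1 `COc1cc(C(c2ccc(O)c(OC)c2)[C@H](C)[C@H](C)CO)ccc1O` is known in this assay only as a limit: compound 1 gives > 100000 nM. Compound 2 `COc1cc(C(c2ccc(O)c(OC)c2)[C@@H](CO)C(C)C)ccc1O` is likewise reported as a limit, > 100000 nM. Among the measured compounds shown here, the one numbered value sits with compound 3 `COc1cc(C(c2ccc(O)c(OC)c2)[C@@H](C)[C@H](C)CF)ccc1O`, which in this assay gives 32000 nM. The two measured steps that move off the limit are an at least 3.1-fold lower number from compound 1 to compound 3 (0.49 log units; beyond the scatter) and an at least 3.1-fold lower number from compound 2 to compound 3 (0.49 log units; beyond the scatter); their size is readable only as a lower bound, because the limit of > 100000 nM in this assay, at which 2 of the 3 values shown sit, caps what can be seen at the starting end. The step between compound 1 and compound 2, a step that the two limits leave unreadable from compound 1 to compound 2, says nothing about direction.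

Compound 4 `COc1cc(C(c2ccc(O)c(OC)c2)[C@H](C)[C@@H](C)CF)ccc1O` carries the change (1-(fluoromethyl)ethyl in place of 1-(hydroxymethyl)ethyl on a saturated chain carbon bound to two saturated chain carbons). This is the same exchange of a hydroxymethyl for a fluoromethyl that took compound 3 off the limit, so a lowering of the number beyond the scatter is expected, of about the size seen in an at least 3.1-fold lower number from compound 1 to compound 3 (0.49 log units; beyond the scatter). The step expected is an at least 3.1-fold lower number from compound 1 to compound 4 (0.49 log units; beyond the scatter). For compound 4 the estimate is 32000 nM, in the range 10000 nM to 100000 nM.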

Compound 4, half-maximal inhibitory concentration: 45000 nM
Compound 4: middle estimate off by 1.4-fold (0.15 log units), on the low side, within the range that was stated.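

In this assay, the exchange of 1-(hydroxymethyl)ethyl for 1-(fluoromethyl)ethyl on a saturated chain carbon bound to two saturated chain carbons gives an at least 2.2-fold lower number from compound 1 to compound 4 (0.34 log units; beyond the scatter), and the second hydroxymethyl compound gives an at least 2.2-fold lower number from compound 2 to compound 4 (0.34 log units; beyond the scatter); both sizes are lower bounds only, set by an assay limit: the limit of > 100000 nM in this assay, at which 2 of the 4 values shown sit. The mirror-image pair gives a 1.4-fold higher number from compound 3 to compound 4 (0.15 log units; within the scatter), so inverting all stereocentres leaves no readable difference: the fact that compounds 3 and 4 differ only in the configuration as drawn. Both fluoromethyl compounds therefore stand off the limit in either drawn configuration, which compound 3 alone could not show.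

Going by these compounds, how far the two hydroxymethyl compounds actually lie from this pair stays open. Also open, on these data alone, is what an aminomethyl group, a carboxylic acid or a longer chain would give at this place.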